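Terminal aryl swap on the cyclohexanecarboxamide series

The source may hold more compounds than are shown below. What is called first, only, known or untested is meant among the compounds shown, and "the series" means these compounds.

Compound 3 `COC(=O)/C=C/c1cccc(N(Cc2ccc(-c3cccc(Cl)c3)cc2)C(=O)C2CCCCC2)c1` gives 94 nM in an assay on isolated protein with Bile acid receptor (Homo sapiens) as the target; on this read-out lower numbers stand for an effect already at smaller amounts and higher numbers for an effect only at larger amounts of compound. Among the three measured compounds it holds the second highest number: compound 1 `COC(=O)/C=C/c1cccc(N(Cc2ccc(/C=C/c3ccccc3F)cc2)C(=O)C2CCCCC2)c1` with 64 nM lies within the scatter of it, while compound 2 `COC(=O)/C=C/c1cccc(N(Cc2ccc(/C=C/c3ccccn3)cc2)C(=O)C2CCCCC2)c1` with 309 nM lies beyond the scatter (a 3.3-fold lower number from compound 2 to compound 3 (0.52 log units; beyond the scatter)). The step of a 1.5-fold higher number from compound 1 to compound 3 (0.17 log units; within the scatter) stays within the scatter, and a 4.8-fold higher number from compound 1 to compound 2 (0.68 log units; beyond the scatter) is the only modest move in the set.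

Compound 4 `COC(=O)/C=C/c1cccc(N(Cc2ccc(-c3c(OC)cccc3OC)cc2)C(=O)C2CCCCC2)c1` carries the change (2,6-dimethoxyphenyl in place of 3-chlorophenyl on an aromatic carbon). Within the data shown here, no measured step exchanges one substituted phenyl for another on this aromatic carbon; the nearest precedents are a 1.5-fold higher number from compound 1 to compound 3 (0.17 log units; within the scatter) and a 3.3-fold lower number from compound 2 to compound 3 (0.52 log units; beyond the scatter), which show that replacing the terminal group on this carbon moves this assay by at most a modest amount. On that basis a step of a 1.6-fold higher number from compound 3 to compound 4 (0.20 log units; within the scatter) is expected for compound 4, that is, no change beyond the scatter. Compound 4 is therefore estimated at 150 nM in this assay, with a range from 45 nM to 500 nM.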

Compound 4, half-maximal effective concentration: 77 nM
Beside the measured number, compound 4's estimate is 1.9-fold (0.29 log units) above it, and the stated range covers the measured number.
By their numbers in this assay, from the lowest: compounds 1, 4 and 3 (each within the scatter of the next); then compound 2.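

Exchanging one substituted phenyl for another on this aromatic carbon, para to a large group, leaves this assay unmoved (a 1.2-fold lower number from compound 3 to compound 4 (0.09 log units; within the scatter)), even though 2,6-dimethoxyphenyl enters with 2 hydrogen-bond acceptors and 10 heavy atoms against 0 and 7 for 3-chlorophenyl. 2,6-Dimethoxyphenyl also stays level with 2-(2-fluorophenyl)ethenyl (a 1.2-fold higher number from compound 1 to compound 4 (0.08 log units; within the scatter)) but separates from 2-(pyridin-2-yl)ethenyl (a 4.0-fold lower number from compound 2 to compound 4 (0.60 log units; beyond the scatter)), so among the four terminal groups only compound 2 stands apart from the rest. Nothing on hand accounts for this tolerance.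

The compounds shown leave open whether an amine or a carboxylic acid on the terminal phenyl would stay in this range. They also leave open whether a single methoxy group would behave as 2,6-dimethoxyphenyl does.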